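The source may report more compounds than this note shows. Statements on the series, on what has been measured and on what is new or still open speak of the compounds shown alone.

Measured compounds:
- compound 1, `COc1cccc(/C=C2\CCC/C(=C\c3cccc(Cl)c3)C2=O)c1OC`: > 20000 nM
- compound 2, `COc1ccccc1/C=C1\CCC/C(=C\c2cccc(OC)c2OC)C1=O`: > 20000 nM
- compound 3, `COc1cccc(/C=C2\CCC/C(=C\c3ccc(O)cc3)C2=O)c1OC`: > 20000 nM

In a functional assay on A549 cells (Homo sapiens) for cytotoxicity, read by MTT assay, with a stated time of 72 h (a lower number here means a stronger inhibitor, a higher number a weaker inhibitor), compound 1 gives only a limit, > 20000 nM, and not a number. Compound 2 also gives only a limit in this assay, > 20000 nM. Compound 3 likewise gives only a limit, > 20000 nM. Compound 1 therefore stands at the same limit as the other two; the steps a step that the two limits leave unreadable from compound 1 to compound 2, a step that the two limits leave unreadable from compound 1 to compound 3 and a step that the two limits leave unreadable from compound 2 to compound 3 cannot be read because of the limit of > 20000 nM in this assay, at which 3 of the 3 values shown sit.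

Compound 4, `COc1cccc(/C=C2\CCC/C(=C\c3ccc(O)c(O)c3)C2=O)c1OC`, differs from compound 1 in one place: 3,4-dihydroxyphenyl in place of 3-chlorophenyl on a double-bonded chain carbon bound to a double-bonded ring carbon. Among the measured compounds shown here, the steps that bear on this change are those from compound 1 to compound 2 and from compound 1 to compound 3, both of which are unreadable, so they give no size or direction to carry over; they only show that exchanging this aryl group has not yet produced a value within the assay's reach. For compound 4 a step that the limit leaves unreadable from compound 1 to compound 4 is therefore expected, that is, none beyond the scatter, with the result most likely again a limit. The estimate for compound 4 in this assay is 25000 nM, expected to fall between 8000 nM and 60000 nM.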

Compound 4, half-maximal inhibitory concentration: > 20000 nM
Compound 4 ended at the assay's limit (the forecaster's own chance of this, stated with the estimate: 70%); the middle value is on the limit's open side.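

Compound 4, like compound 1, compound 2 and compound 3, gives only a limit in this assay, and its steps to those three cannot be read because no compound here has an actual number: the limit of > 20000 nM in this assay, at which 4 of the 4 values shown sit.

The compounds shown leave open how these aryl groups on the shared core rank against one another.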